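The compounds below may be only part of what the source reports. "The series", "measured", "known", "first", "only" and "open" are said of these compounds alone.

Among the measured compounds shown here, compound 1, with the structure `O=C(N1CCC(c2nc(-c3ccc4ccccc4n3)no2)CC1)N1CCCc2ccccc21`, is one of two compounds measured here in a functional assay on Shh Light II cells (Mus musculus) for inhibition, read by a luciferase reporter; on this read-out higher numbers stand for weaker inhibition and lower numbers for stronger inhibition. In this assay compound 1 gives 2300 nM, the higher of the two numbers and therefore the weaker inhibition of the pair. The other measured compound, compound 2 with the structure `Cn1c(-c2noc(C3CCN(C(=O)NC4CCCCC4)CC3)n2)nc2ccccc21`, gives 89 nM in this assay, a number that lies far below that of compound 1, well beyond the usual scatter. Compound 2 differs from compound 1 in more than one place, so that gap cannot be assigned to any single change.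

The step considered next leads from compound 1 to compound 3, whose structure is `O=C(Nc1cccc2cccnc12)N1CCC(c2nc(-c3ccc4ccccc4n3)no2)CC1`. The difference between them is (quinolin-8-yl)amino in place of 1,2,3,4-tetrahydroquinolin-1-yl on a carbonyl carbon. The urea of compound 1 carries no hydrogen on either nitrogen, whereas compound 3 gains a hydrogen-bond donor and a hydrogen-bond acceptor in the entering group. For the measured compounds named here, the single measured comparison offers no direct parallel for this change, so the expected step from compound 1 to compound 3 is a moderate move toward stronger inhibition, a 3.8-fold lower number from compound 1 to compound 3 (0.58 log units; beyond the scatter), and compound 3 is estimated at 600 nM, within a range from 120 nM to 3000 nM.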

Compound 3, half-maximal inhibitory concentration: 1400 nM
For compound 3 the middle estimate is 2.3-fold (0.37 log units) below the measured one; measured number inside the range.
By their numbers in this assay, from the lowest: compound 2; then compounds 3 and 1 (each within the scatter of the next).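

In this assay putting (quinolin-8-yl)amino in place of 1,2,3,4-tetrahydroquinolin-1-yl on a carbonyl carbon gives a 1.6-fold lower number from compound 1 to compound 3 (0.22 log units; within the scatter) and so leaves compound 1 and compound 3 indistinguishable on this read-out. At this position, one group with two six-membered rings can therefore be exchanged for another without a difference that the assay can resolve, even though the entering group has a hydrogen-bond donor and a hydrogen-bond acceptor and the leaving group has neither. No measurement available here offers an explanation for this result.

Going by these compounds, this single exchange alters the ring system, the amide hydrogen and the ring nitrogen all at once, so the share of each in the outcome remains unknown. Also open, on these data alone, is whether a plain phenylamino group, which keeps the amide hydrogen but has no ring nitrogen, or a small dimethylamino group on the same carbonyl carbon would likewise leave the number within the scatter of compound 1 and compound 3.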